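This account rests on a few compounds, and the source may have more. Where it says the series, first, only, none or still open, it means among the compounds named here.

Of the compounds shown here, three built on the same core have been tested in an assay on isolated protein for inhibition of MAP kinase-interacting serine/threonine-protein kinase 1 (Homo sapiens), read by HTRF, in the presence of a further agent that is not named here; a higher number here means a weaker inhibitor, a lower number a stronger inhibitor. Compound 1 `O=C(c1cccc(C#Cc2ccccc2Nc2ncnc3ccc(Cl)nc23)c1)N1CCOCC1` gives only a limit of the assay, > 10000 nM. Compound 2 `Cc1c(C(=O)N2CCOCC2)oc2ccc(Nc3ncnc4ccc(Cl)nc34)cc12` likewise gives only a limit, > 10000 nM. Compound 3 `Cc1c(C(=O)N(C)C)oc2ccc(Nc3ncnc4ccc(Cl)nc34)cc12` also gives only a limit, > 10000 nM. For the measured compounds named here, because all three readings sit at the limit of > 10000 nM in this assay, at which 3 of the 3 values shown sit, no number separates any of them, and the one step between measured compounds, a step that the two limits leave unreadable from compound 2 to compound 3, has no readable size or direction. Compound 4 `CCCNC(=O)c1oc2ccc(Nc3ncnc4ccc(Cl)nc34)cc2c1C` differs from compound 3 in one place: propylamino in place of dimethylamino on a carbonyl carbon. Going by the values given here, the only measured step at the carbonyl carbon, a step that the two limits leave unreadable from compound 2 to compound 3, offers no size to lean on, so no reading so far foretells whether this change helps or hurts. Compound 4 is therefore expected to sit where compound 3 sits, most likely again at the limit, with an estimate of 15000 nM and a range from 7000 nM to 50000 nM. The step that the limit leaves unreadable from compound 3 to compound 4 is expected to be none beyond the scatter.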

Compound 4, half-maximal inhibitory concentration: > 10000 nM
Compound 4: only a limit was reported; the forecaster's own chance of this, stated with the estimate: 85%; the middle value is on the limit's open side.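

No new step can be read from compound 2 or compound 3 to compound 4, because each reading is a limit and not a number: the limit of > 10000 nM in this assay, at which 4 of the 4 values shown sit.

The compounds shown leave open how strongly any of them inhibits the kinase, and whether exchanging the group on the carbonyl carbon changes that strength at all.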